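A few compounds are considered here, and "the series" means these few. Any claim that something is new, unique, unknown or untested is made for them only; others in the source may bear on it.

Working notes on the series. Among the measured compounds shown here, in a functional assay on KB cells (Homo sapiens) for inhibition, read by MTT assay, with a stated time of 24 h, tested at 100 ug/mL (on this read-out lower numbers stand for less inhibition of growth and higher numbers for more inhibition of growth at the one concentration tested), compound 1 `CC(=O)SCCC(CCCCC(=O)Nc1ccccc1)SC(C)=O` gives 23%, while compound 2 `CC(=O)SCCC(CCCCC(=O)Nc1ccccc1Cl)SC(C)=O` gives 6.93%, the lower of the two numbers so far. Next comes compound 3 `CC(=O)SCCC(CCCCC(=O)Nc1cccc(Cl)c1)SC(C)=O`: 3-chlorophenyl in place of 2-chlorophenyl on an amide-type nitrogen, with 3-chlorophenyl in place of 2-chlorophenyl on an amide-type nitrogen. For the measured compounds named here, only one measured step bears on this: a number 16.1 percentage points lower from compound 1 to compound 2 (beyond the scatter), a modest drop on placing chloro in place of hydrogen on an aromatic carbon. Going by the values given here, no measured compound separates the presence of chloro from its position, so this single step gives only weak guidance. Compound 3 keeps the chloro, so only a partial return towards compound 1 is expected in this assay. The expected move is small and upward, within the scatter: a number 7.1 percentage points higher from compound 2 to compound 3 (within the scatter). For compound 3 the estimated value is 14%, with an expected range of 3% to 29%.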

Compound 3, percent growth inhibition at one concentration: 48.8%
The estimate for compound 3 lay 34.8 percentage points below the measured number, outside the stated range (above it).
By their numbers in this assay, from the lowest: compound 2; then compound 1; then compound 3.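

In this assay, the position of the chloro matters on its own: with the atoms unchanged, 3-chlorophenyl in place of 2-chlorophenyl on the amide-type nitrogen gives a number 41.9 percentage points higher from compound 2 to compound 3 (beyond the scatter), a large step. Adding chloro therefore has no single direction in this small set, since a number 25.8 percentage points higher from compound 1 to compound 3 (beyond the scatter) runs opposite to the earlier a number 16.1 percentage points lower from compound 1 to compound 2 (beyond the scatter), and the drop seen before belongs to 2-chlorophenyl rather than to chloro as such. Nothing available explains why the two positions differ.

The compounds shown leave open whether the rise belongs to chloro in particular or would also appear with 3-bromophenyl or 3-methoxyphenyl on the same nitrogen. They also leave open whether the order of compound 1, compound 2 and compound 3 holds at other concentrations, since each has a number at only one.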